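The compounds below may be only part of what the source reports. "The series", "measured", "known", "first", "only" and "open" are said of these compounds alone.

Measured in a functional assay on HepG2 cells (Homo sapiens) for cytotoxicity, with a stated time of 72 h (on this read-out lower numbers stand for an effect already at smaller amounts and higher numbers for an effect only at larger amounts of compound), each value a limit of the assay:

- Compound 1 `C=C[C@@](C)(/C=C/c1ccc(O)cc1)CCC1OC1(C)C`: > 52000 nM
- Compound 2 `C=C[C@@](C)(/C=C/c1ccc(O)cc1)CC/C=C/C(=O)OCc1ccccc1`: > 52000 nM
- Compound 3 `COc1ccc(/C=C/[C@@](C)(/C=C/c2ccc(O)c(C=O)c2)CCC=C(C)C)cc1`: > 26000 nM

None of these compounds gives an actual number, so no measured step is available as a guide. Compound 3 stands only at a limit, > 26000 nM. Compound 4 `COc1ccc(/C=C/[C@@](C)(/C=C/c2ccc(O)c(/C=C/C(C)=O)c2)CCC=C(C)C)cc1` carries 2-acetylethenyl in place of formyl on an aromatic carbon, ortho to a hydroxy group (2-acetylethenyl in place of formyl on an aromatic carbon). The expectation rests on compound 3, whose limit is > 26000 nM. The step expected in this assay is a step that the limit leaves unreadable from compound 3 to compound 4, with none beyond the usual scatter. The estimated value for compound 4 is 30000 nM, with an expected range of 10000 nM to 60000 nM.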

Compound 4, half-maximal effective concentration: > 52000 nM
Compound 4 was reported as a limit (the forecaster's own chance of this, stated with the estimate: 60%); middle value at least 1.7-fold (0.23 log units) away from the limit.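

Among the compounds shown here, compound 3 and compound 4 are both reported only as limits, so no step between them can be read. Going by these compounds, whether 2-acetylethenyl in place of formyl changes the effect at all, and at what amount either compound would act, stays open.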